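This account rests on a few compounds, and the source may have more. Where it says the series, first, only, none or still open, it means among the compounds named here.

Measured in a functional assay on MCF7 cells (Homo sapiens) for antiproliferative activity, read by MTT assay; on this read-out lower numbers stand for stronger inhibition and higher numbers for weaker inhibition:
- compound 1 `CCCCC/C=C\C/C=C\CCCCCCCc1cc(=O)c2c(O)c(C)c(OCOC)c(C)c2o1`: > 84100 nM
- compound 2 `CCCC/C=C/CCCCCCCCCC1(O)CC(=O)C2=C(O)C(C)C(O)C(C)=C2O1`: 17500 nM

The entry for compound 1 is a limit. Among the compounds with values here, compound 2 holds the only actual number, 17500 nM. Compound 3 `CCCCCCCCCCCCCCCC1(O)CC(=O)C2=C(O)C(C)C(O)C(C)=C2O1` keeps the core of compound 2 and carries hexyl in place of hex-1-en-1-yl on a saturated chain carbon, nine bonds along the chain from a saturated ring carbon. Within the data shown here, no measured pair sizes this change, so in this assay no shift beyond the scatter is expected, with any small drift more likely towards weaker inhibition. The expected size of a 1.3-fold higher number from compound 2 to compound 3 (0.10 log units; within the scatter) is therefore small. The estimate for compound 3 is 22000 nM, with a range of 9000 nM to 60000 nM.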

Compound 3, half-maximal inhibitory concentration: > 100000 nM
Compound 3 gave a limit, no number; the forecaster's own chance of this, stated with the estimate: 15%; middle value at least 4.5-fold (0.65 log units) away from the limit.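

Saturating the chain is not neutral at this position: in this assay, the change to hexyl gives an at least 5.7-fold higher number from compound 2 to compound 3 (0.75 log units; beyond the scatter). Compound 3 gives > 100000 nM, which is a limit and not a number. The true size of the step stays unknown because compound 3 sits at a limit: the limit of > 100000 nM in this assay, at which 1 of the 3 values shown sits.

Still open, going by these compounds, is whether a longer chain, or a chain ending in an amine or a carboxylic acid, would give a measurable number on this core. On these data alone, with a single actual number, the effect of the double bond in other chains also stays open.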